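The source may report more compounds than this note shows. Statements on the series, on what has been measured and on what is new or still open speak of the compounds shown alone.

In a functional assay on DLD-1 cells (Homo sapiens) for cytotoxicity (on this read-out lower numbers stand for stronger inhibition and higher numbers for weaker inhibition), compound 3 `CCC1C(=O)N(CCCCCOc2ccc(Cl)cc2)/C(=N\C#N)N1c1ccncc1` gives 4080 nM. Compound 2 `CC1C(=O)N(CCCCCOc2ccc(Cl)cc2)/C(=N\C#N)N1c1ccncc1` gives 4110 nM in this assay, and compound 1 `N#C/N=C1\N(CCCCCOc2ccc(Cl)cc2)C(=O)CN1c1ccncc1` gives 3800 nM; the three numbers sit close together: a 1.1-fold higher number from compound 1 to compound 2 (0.03 log units; within the scatter), a 1.1-fold higher number from compound 1 to compound 3 (0.03 log units; within the scatter) and a 1.0-fold lower number from compound 2 to compound 3 (0.00 log units; within the scatter). Compound 4 `N#C/N=C1\N(CCCCCOc2ccc(Cl)cc2)C(=O)C(c2ccccc2)N1c1ccncc1` differs from compound 3 in that (phenyl in place of ethyl on a saturated ring carbon). The measured steps at this ring carbon, hydrogen to methyl, hydrogen to ethyl and methyl to ethyl, all stayed within the scatter. None of them brought in an aromatic ring, so the phenyl group reaches beyond what was measured, but nothing measured points to a change in this assay. Compound 4 is therefore expected to give 4000 nM in this assay, within 1800 nM to 9000 nM. The step expected is a 1.0-fold lower number from compound 3 to compound 4 (0.01 log units; within the scatter), none beyond the scatter.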

Compound 4, half-maximal inhibitory concentration: 337 nM
For compound 4 the middle estimate is 12-fold (1.07 log units) above the measured one; measured number below the stated range.
By their numbers in this assay, from the lowest: compound 4; then compounds 1, 3 and 2 (each within the scatter of the next).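

Phenyl on this saturated ring carbon matters in this assay where smaller groups did not: the step is large against ethyl (a 12-fold lower number from compound 3 to compound 4 (1.08 log units; beyond the scatter)), against methyl (a 12-fold lower number from compound 2 to compound 4 (1.09 log units; beyond the scatter)) and against hydrogen (an 11-fold lower number from compound 1 to compound 4 (1.05 log units; beyond the scatter)). The position is therefore not indifferent to what it carries, although hydrogen, methyl and ethyl alone gave no sign of this. No evidence here explains the gain. From the compounds shown here alone, whether the aromatic ring itself is needed stays open, as a cyclohexyl group would test that. Going by these compounds, how a benzyl group or a substituted phenyl, such as 4-chlorophenyl, would compare also stays open.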